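Para-substituent swap on the aryl ring: acetyl to bromo

A few compounds are considered here, and "the series" means these few. Any claim that something is new, unique, unknown or untested is made for them only; others in the source may bear on it.

Measured so far:
compound 1 `c1ccc(-c2cn3ccnc3c(-c3ccc4ncn(C5CCCCC5)c4c3)n2)cc1`: 59.5%
compound 2 `CC(=O)c1ccc(-c2cn3ccnc3c(-c3ccc4ncn(C5CCCCC5)c4c3)n2)cc1`: 15.9%

In a functional assay on HCT-116 cells (Homo sapiens) for inhibition, read by sulforhodamine B assay, with a stated time of 48 h, tested at 10 uM (a higher number here means more inhibition at the concentration tested (going by the name of the read-out), a lower number less inhibition), compound 2 stands lowest of the two numbers; its nearest neighbour, compound 1, lies higher by the step of a number 43.6 percentage points lower from compound 1 to compound 2 (beyond the scatter). Compound 3 `Brc1ccc(-c2cn3ccnc3c(-c3ccc4ncn(C5CCCCC5)c4c3)n2)cc1` differs from compound 2 as follows: bromo in place of acetyl on an aromatic carbon. For the measured compounds named here, no measured step covers bromo itself; the only step on record, a number 43.6 percentage points lower from compound 1 to compound 2 (beyond the scatter), shows that adding acetyl at this position cost much inhibition. Removing acetyl is therefore expected to recover part of that loss, with bromo's own effect unknown. Compound 3 is estimated at 40% (range 15% to 65%), an expected step of a number 24.1 percentage points higher from compound 2 to compound 3 (beyond the scatter).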

Compound 3, a percentage reported as inhibition, at one concentration (the size of the read-out at that concentration, not a potency): 31.2%
Beside the measured number, compound 3's estimate is 8.8 percentage points above it; low and high end bracket the measured number.
By their numbers in this assay, from the lowest: compound 2; then compound 3; then compound 1.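

In this assay, the change from 4-acetylphenyl to 4-bromophenyl recovers only part of the loss seen with acetyl (a number 15.3 percentage points higher from compound 2 to compound 3 (beyond the scatter)). Bromo in place of hydrogen also costs inhibition (a number 28.3 percentage points lower from compound 1 to compound 3 (beyond the scatter)), so the drop at this place is not confined to acetyl, and both substituted compounds remain below the unsubstituted compound 1. Nothing available explains the size of either step.

Still open, on these data alone, is whether an amine, a carboxylic acid or a methoxy group at this place would also lower inhibition. As far as these compounds go, whether any group here can match or exceed compound 1 also remains open.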